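This account rests on a few compounds, and the source may have more. Where it says the series, first, only, none or still open, it means among the compounds named here.

Measured in a functional assay (aorta) with Rattus norvegicus as the target; a higher number here means that more compound is needed for the effect, a lower number that less compound is needed:
- compound 1 `CN(C)/C(=N\C#N)C1=CC(C)(C)Oc2ccc([N+](=O)[O-])cc21`: > 31600 nM
- compound 2 `CNC(=O)C1=CC(C)(C)Oc2ccc([N+](=O)[O-])cc21`: 10.7 nM

The entry for compound 1 is a limit of the assay and not a number. Among the compounds with values here, compound 2, at 10.7 nM, holds the only actual number so far. Compound 3 `CN(C)C(=O)C1=CC(C)(C)Oc2ccc([N+](=O)[O-])cc21` has not yet been measured. It differs from compound 2 by methyl in place of hydrogen on an amide-type nitrogen.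

Within the data shown here, one measured step bears on this change: an at least 2900-fold lower number from compound 1 to compound 2 (3.47 log units; beyond the scatter). That large step replaces a whole group carrying dimethylamino, so it offers only a loose guide. It still suggests that compound 3 will need more compound in this assay, though probably by a smaller margin. The expected change is a 75-fold higher number from compound 2 to compound 3 (1.87 log units; beyond the scatter). For compound 3 the estimated value is 800 nM, with an expected range of 60 nM to 10000 nM.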

Compound 3, half-maximal effective concentration: 129 nM
The estimate for compound 3 lay 6.2-fold (0.79 log units) above the measured number; the range from low to high includes it.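

Compound 2 and compound 3 isolate a single change on the amide-type nitrogen, and in this assay methyl in place of hydrogen gives a 12-fold higher number from compound 2 to compound 3 (1.08 log units; beyond the scatter), so this position is sensitive to even one added methyl. The dimethylcarbamoyl group nevertheless remains far ahead of the group it replaces on the double-bonded ring carbon, with an at least 240-fold lower number from compound 1 to compound 3 (2.38 log units; beyond the scatter). The entry for compound 1 is a limit of the assay and not a number, so that step has no exact size: the limit of > 31600 nM in this assay, at which 1 of the 3 values shown sits.

Going by these compounds, it remains open whether a longer chain on this nitrogen, such as ethyl or propyl, or a cyclic amine such as pyrrolidine in place of dimethylamino, would raise the number further. A single step of this kind also establishes no trend, and a carboxylic acid on the same ring carbon remains untested among the compounds shown.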